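Methyl changes and growth inhibition in a small series

The source may hold more compounds than are shown below. What is called first, only, known or untested is meant among the compounds shown, and "the series" means these compounds.

Measured values in a functional assay on OVCAR-3 cells (Homo sapiens); on this read-out lower numbers stand for stronger inhibition of growth and higher numbers for weaker inhibition of growth:
Compound 1 `COc1ccccc1-c1cc(O)c2ccc(C)nc2n1` gives > 100000 nM as a limit of the assay
Compound 2 `COc1ccccc1-c1cc(O)c2cccnc2n1` gives 47900 nM as a number
Compound 3 `COc1ccccc1-c1cc(O)c2c(C)ccnc2n1` gives 12900 nM as a number

Compound 2 holds the higher of the two values that are actual numbers. Compound 3 lies lower, and compound 1 is known only through its limit.

The unmeasured compound 4 `COc1ccccc1-c1cc(O)c2cc(C)cnc2n1` differs from compound 2 by methyl in place of hydrogen on an aromatic carbon, two atoms from the ring nitrogen. Going by the values given here, two measured steps bear on this change. As far as these compounds go, removing a methyl gave an at least 2.0-fold lower number from compound 1 to compound 2 (0.31 log units; beyond the scatter) and rests on the limit of > 100000 nM in this assay, at which 1 of the 3 values shown sits, so its full size stays open. Adding a methyl at another aromatic carbon gave a 3.7-fold lower number from compound 2 to compound 3 (0.57 log units; beyond the scatter) instead. Read as additions of methyl, these two steps point in opposite directions, so the position of the methyl matters in this small set and neither step transfers directly. A step of modest size is expected in this assay with a slight lean towards a lower number, and a step within the scatter remains quite possible. The expected change is a 1.9-fold lower number from compound 2 to compound 4 (0.28 log units; within the scatter) as an estimate only. For compound 4 the estimated value is 25000 nM with an expected range from 7000 nM to 90000 nM in this assay for now.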

Compound 4, concentration for 50% growth inhibition: 19500 nM
Beside the measured number, compound 4's estimate is 1.3-fold (0.11 log units) above it; the range from low to high includes it.
By their numbers in this assay, from the lowest: compounds 3 and 4 (each within the scatter of the next); then compound 2. At a limit, above all of these: compound 1.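

In this assay, adding a methyl two atoms from the ring nitrogen gives a 2.5-fold lower number from compound 2 to compound 4 (0.39 log units; beyond the scatter). Going by these compounds alone, this is the first reading for this position, and it runs the same way as a 3.7-fold lower number from compound 2 to compound 3 (0.57 log units; beyond the scatter), so two methyl placements on the core of compound 2 now go with a lower number, while the methyl of compound 1 goes against them. Compound 3 at 12900 nM and compound 4 at 19500 nM lie within the scatter of each other, so these values do not separate the two placements.

As far as these compounds go, the distance of compound 1 from the others stays open because its value is only a limit: the limit of > 100000 nM in this assay, at which 1 of the 4 values shown sits. From the compounds shown here alone, whether the lower number at this position belongs to methyl alone also stays open, and an ethyl chain, an amine or a carboxylic acid on the same aromatic carbon would be needed to show how far the change extends beyond this one small group.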